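The source may hold more compounds than are shown below. What is called first, only, known or untested is meant among the compounds shown, and "the series" means these compounds.

Measured so far:
compound 1, `Nc1ncc(-c2nc3ccccc3s2)c(N[C@@H]2C[C@H](CO)[C@@H](O)[C@H]2O)n1`: > 25000 nM
compound 2, `Cc1nc(NCC2CC2)nc(N[C@@H]2C[C@H](CO)[C@@H](O)[C@H]2O)c1-c1nc2ccccc2s1`: 8000 nM

In an ADME assay on cells (Homo sapiens) for cytotoxicity, read by polymerase chain reaction, with a stated time of 3 days (a higher number here means that more compound is tolerated, a lower number that less compound is tolerated), compound 1 gives > 25000 nM, which is a limit of the assay and not a number, (the limit of > 25000 nM in this assay, at which 1 of the 2 values shown sits). Within the data shown here, compound 2 gives 8000 nM and so stands as the only measured number of the pair. Compound 3, `Cc1nc(NCc2ccccc2)nc(N[C@@H]2C[C@H](CO)[C@@H](O)[C@H]2O)c1-c1nc2ccccc2s1`, differs from compound 2 by phenyl in place of cyclopropyl on a saturated chain carbon bound to a nitrogen on an aromatic ring. Among the measured compounds shown here, no measured step covers this change, so in this assay I expect at most a small step, within the scatter, if anything towards less tolerated. Compound 3 is therefore estimated at 6000 nM, between 2000 nM and 20000 nM, a step of a 1.3-fold lower number from compound 2 to compound 3 (0.12 log units; within the scatter).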

Compound 3, half-maximal cytotoxic concentration: 9000 nM
Beside the measured number, compound 3's estimate is 1.5-fold (0.18 log units) below it, within the range that was stated.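

In this assay, phenyl in place of cyclopropyl on a saturated chain carbon bound to a nitrogen on an aromatic ring gives a 1.1-fold higher number from compound 2 to compound 3 (0.05 log units; within the scatter). Among these compounds, this is the first single-place comparison, and it shows that a six-membered aromatic ring and a three-membered non-aromatic ring read alike at this position. Nothing measured here bears on why the two compounds read alike.

Going by these compounds, whether a carboxylic acid, an amine or a longer chain at this place would read differently stays open. On these data alone, the effect of a substituent on the phenyl ring also stays open.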